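Urea in place of amide on the benzothiazole series

The source may report more compounds than this note shows. Statements on the series, on what has been measured and on what is new or still open speak of the compounds shown alone.

Compound 3 `CNC(=O)c1cc(Oc2ccc3nc(NC(=O)c4cc(Cl)cc(Cl)c4)sc3c2)ccn1` is the weakest of the three measured compounds in a functional assay on HCT-116 cells (Homo sapiens) for inhibition, read by MTT assay, with a stated time of 2 days, tested at 100 uM (on this read-out lower numbers stand for less inhibition of growth and higher numbers for more inhibition of growth at the one concentration tested), where it gives 15.8%. Its nearest neighbour on the numbers is compound 1 `CNC(=O)c1cc(Oc2ccc3nc(NC(=O)c4ccc(Cl)cc4Cl)sc3c2)ccn1`, which in this assay gives 64.4%; the furthest is compound 2 `CNC(=O)c1cc(Oc2ccc3nc(NC(=O)Nc4ccc(C5CCN(C(C)C)CC5)cc4)sc3c2)ccn1`, which gives 95.5%. Going by the values given here, the one single-point step that is known, a number 48.6 percentage points lower from compound 1 to compound 3 (beyond the scatter), shows that moving chlorine atoms around the aryl ring alone shifts the read-out by a large amount.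

Compound 4 `CNC(=O)c1cc(Oc2ccc3nc(NC(=O)Nc4ccc(Br)cc4)sc3c2)ccn1` differs from compound 3 in that ((4-bromophenyl)amino in place of 3,5-dichlorophenyl on a carbonyl carbon). Among the compounds with values here, no measured step covers this kind of change; compound 2 is the only other compound that carries an amino group on that carbonyl carbon, but it differs from compound 4 in more than one place, so its value shows only that such a compound can sit at the top of the range.

Given the large swing in a number 48.6 percentage points lower from compound 1 to compound 3 (beyond the scatter) and the high value of compound 2, the step is expected to rise, a number 39.2 percentage points higher from compound 3 to compound 4 (beyond the scatter), with wide uncertainty. Compound 4 is therefore estimated at 55%, within 20% to 90%.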

Compound 4, percent growth inhibition at one concentration: 80%
The estimate for compound 4 lay 25 percentage points below the measured number; the range from low to high includes it.
By their numbers in this assay, from the lowest: compound 3; then compound 1; then compound 4; then compound 2.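

In this assay, (4-bromophenyl)amino in place of 3,5-dichlorophenyl on a carbonyl carbon gives a number 64.2 percentage points higher from compound 3 to compound 4 (beyond the scatter), and the same group in place of 2,4-dichlorophenyl gives a number 15.6 percentage points higher from compound 1 to compound 4 (beyond the scatter), so the group that enters stands above both dichlorophenyl groups, by very different margins. Bromo in place of 1-isopropylpiperidin-4-yl on an aromatic carbon gives a number 15.5 percentage points lower from compound 2 to compound 4 (beyond the scatter), which shows that the high read-out of compound 2 does not depend entirely on that piperidine group, even though the step lies beyond the scatter. No measurement at hand explains any of these steps.

Each step from a dichlorophenyl compound to compound 4 changes the amino link and the halogen pattern together, so the share of each in the rise remains unresolved. A (3,5-dichlorophenyl)amino group on that carbonyl carbon would separate the two, while a primary amine or a carboxylic acid in place of the bromo would show how far the upper end of the range extends.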